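The source may hold more compounds than are shown below. What is called first, only, known or untested is meant among the compounds shown, and "the series" means these compounds.

In a functional assay on UACC-62 cells (Homo sapiens) (a higher number here means a weaker inhibitor of growth, a lower number a stronger inhibitor of growth), compound 3 (`O=S(=O)(/C=C/c1ccc(Cl)c(Cl)c1)Cc1ccc(Nc2ncnc3ccc(Br)cc23)cc1`) gives 30000 nM. Compound 1 (`O=S(=O)(/C=C/c1ccc(Cl)c(Cl)c1)Cc1ccc(Nc2ncnc3ccccc23)cc1`) gives 21000 nM, within the scatter of compound 3, while compound 2 (`CC(C)(C)c1cc(/C=C/S(=O)(=O)Cc2ccc(Nc3ncnc4ccccc34)cc2)cc(C(C)(C)C)c1O`) shows a lower number than both at 6000 nM.

Compound 4 (`O=S(=O)(/C=C/c1ccc(Cl)cc1Cl)Cc1ccc(Nc2ncnc3ccc(Br)cc23)cc1`) has the same atoms as compound 3, joined differently: 2,4-dichlorophenyl in place of 3,4-dichlorophenyl on a double-bonded chain carbon bound to a double-bonded chain carbon. Within the data shown here, only one measured step is available as a guide, and it is a loose one: a 1.4-fold higher number from compound 1 to compound 3 (0.15 log units; within the scatter). That step is bromo in place of hydrogen on an aromatic carbon, so it is a different change made elsewhere on the molecule. Among the measured compounds shown here, compound 2 differs from the others in more than one place and gives no clean step. For the measured compounds named here, no measured pair shows what this swap of dichlorophenyl groups does, so the uncertainty stays wide.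

No step beyond the scatter is expected in this assay, and the estimated change is a 1.2-fold lower number from compound 3 to compound 4 (0.08 log units; within the scatter). The expected value for compound 4 is 25000 nM, with an estimated range from 10000 nM to 60000 nM.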

Compound 4, concentration for 50% growth inhibition: 2000 nM
Estimate against measurement, compound 4: 13-fold (1.10 log units) above, and the stated range ends above it.
By their numbers in this assay, from the lowest: compound 4; then compound 2; then compounds 1 and 3 (each within the scatter of the next).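

In this assay, rearranging the two chlorines from 3,4-dichlorophenyl to 2,4-dichlorophenyl adds and removes no atoms, yet gives a 15-fold lower number from compound 3 to compound 4 (1.18 log units; beyond the scatter). Among these compounds, the only earlier single-place step, a 1.4-fold higher number from compound 1 to compound 3 (0.15 log units; within the scatter), stayed within the scatter, so this is the first sign that growth inhibition is sensitive to a change in one place, here the aryl group on the double-bonded chain carbon. No measurement shown here accounts for the size of this step.

Going by these compounds, it remains open whether the same swap gives a similar step on the core of compound 1, which has hydrogen where compound 3 and compound 4 carry bromo. It is also unknown how the number would respond if methoxy or fluoro replaced either chlorine of the 2,4-dichlorophenyl group.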